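This account rests on a few compounds, and the source may have more. Where it says the series, first, only, none or still open, it means among the compounds named here.

Measured compounds:
compound 1 `CCCCCCCC/C=C\CCCCCCCC(=O)OC[C@@H](C)OP(=O)(O)OC[C@H](N)C(=O)O` — 12.8%
compound 2 `CCCCCCCC/C=C\CCCCCCCC(=O)OC[C@@H](COC)OP(=O)(O)OC[C@H](N)C(=O)O` — 12.9%
compound 3 `CCCCCCCC/C=C\CCCCCCCC(=O)OC[C@H](COC)OP(=O)(O)OC[C@H](N)C(=O)O` — 7.5%

In an assay on HEK293 cells for agonist activity at probable G-protein coupled receptor 34 (Mus musculus), with a stated time of 1 h (on this read-out higher numbers stand for larger maximal responses and lower numbers for smaller maximal responses), compound 2 gives 12.9%. Its two neighbours sit close by: the step of a number 0.1 percentage points higher from compound 1 to compound 2 (within the scatter) and the step of a number 5.4 percentage points lower from compound 2 to compound 3 (within the scatter) both stay within the usual scatter, so the three numbers cannot be told apart, and all three stand for small maximal responses.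

The unmeasured compound 4 `CCCCCCCC/C=C\CCCCCCCC(=O)OC[C@@H](COCC)OP(=O)(O)OC[C@H](N)C(=O)O` differs from compound 2 at one place: methyl in place of hydrogen on a saturated chain carbon bound to an oxygen on a saturated carbon. Of the measured steps, only one touches the same part of the molecule, the step from compound 1 to compound 2, in which a methoxy entered in place of hydrogen on a saturated chain carbon and the number moved by a number 0.1 percentage points higher from compound 1 to compound 2 (within the scatter), a change within the scatter. Lengthening that methoxy to an ethoxy is a smaller change than adding it in the first place, so no step beyond the scatter is expected in this assay.

Compound 4 is therefore expected to give about 13% in this assay, within a range from 5% to 22%, which means an expected step of a number 0.1 percentage points higher from compound 2 to compound 4 (within the scatter).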

Compound 4, largest response reached (Emax), in percent of the reference or control that the assay uses: 12.3%
For compound 4 the middle estimate is 0.7 percentage points above the measured one; the range from low to high includes it.
By their numbers in this assay, from the lowest: compounds 3, 4, 1 and 2 (each within the scatter of the next).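

In this assay, the step of a number 0.6 percentage points lower from compound 2 to compound 4 (within the scatter) shows that a methyl added on the saturated chain carbon bound to an oxygen on a saturated carbon leaves the maximal response indistinguishable from that of the methoxy compound. The earlier compounds shown here covered only hydrogen and methoxy at this place, and the step of a number 0.5 percentage points lower from compound 1 to compound 4 (within the scatter) brings ethoxy into the same picture, so hydrogen, methoxy and ethoxy cannot be told apart here and all three compounds stay at small maximal responses. Nothing measured here bears on the cause of this flat result.

The compounds shown leave open whether a different kind of group at this place, such as an amine, a carboxylic acid or a longer chain such as butoxy, would give a response beyond the scatter of these values. Within the data shown here, they also leave open how the ethoxy compound would read with the stereocentre at the saturated chain carbon drawn S, as it is in compound 3, since the only pair that differs at that stereocentre carries the methoxy.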